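Diaryl sulfoxides at the dopamine transporter: a thiophene swap

A few compounds are considered here, and "the series" means these few. Any claim that something is new, unique, unknown or untested is made for them only; others in the source may bear on it.

Compound 1, `Cc1nnc(C[S+]([O-])C(c2ccccc2)c2ccccc2)s1`: in an assay on HEK293 cells for inhibition of sodium-dependent dopamine transporter (Homo sapiens), read by scintillation counting, with stated times of 5 min and 1 min (on this read-out lower numbers stand for stronger inhibition and higher numbers for weaker inhibition), it is reported as "not active" (no number reported), with no number attached.
Compound 2, `[O-][S+](Cc1nc(C(F)(F)F)no1)C(c1ccccc1)c1ccccc1`: in this assay compound 2 gives 43700 nM.

The two measured compounds share a benzhydryl sulfoxide core and differ only in the five-membered ring hung on the methylene beside the sulfur. Compound 1 stands without a single number; all that is known is that it did not register as active, while compound 2, its closest measured relative, sits at a very weak level. Within the data shown here, no step between two measured compounds is available, so the size and direction of any change must be guessed from the structures alone.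

Compound 3, `[O-][S+](Cc1ccsc1)C(c1ccccc1)c1ccccc1`, is the next compound. It differs from compound 1 by thiophen-3-yl in place of 5-methyl-1,3,4-thiadiazol-2-yl on a saturated chain carbon bound to a sulfur. With compound 1 giving no number and compound 2 giving only a very weak value, the step is expected to stay within the region of weak inhibition, in either direction, and may again yield no number at all. On that basis compound 3 is estimated at 30000 nM, with a range from 8000 nM to 120000 nM.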

Compound 3, half-maximal inhibitory concentration: 3000 nM
Compound 3: the middle estimate sits 10-fold (1.00 log units) above what was measured, outside the stated range (below it).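

Among these compounds, compound 1 carries no number, and no step from it to compound 3 can be read. The compounds shown leave open how large a change in inhibition comes with passing from 5-methyl-1,3,4-thiadiazol-2-yl to thiophen-3-yl on this chain carbon. No measurement shown here offers an explanation for the value of compound 3.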